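The source may report more compounds than this note shows. Statements on the series, on what has been measured and on what is new or still open speak of the compounds shown alone.

Compound 1 (`CC(C)NC(=O)NC1CC(C)(C)Oc2ccc(Cl)cc21`) is a urea built on the shared core, with isopropyl on the amide-type nitrogen. In a functional assay on T98G cells (Homo sapiens) for inhibition, read by MTT assay, with a stated time of 72 h (on this read-out lower numbers stand for stronger inhibition and higher numbers for weaker inhibition), compound 1 gives only a limit, > 100000 nM, which marks the edge of what the assay can report. Of the two values shown, (the limit of > 100000 nM in this assay, at which 1 of the 2 values shown sits); the other belongs to compound 2 (`CC1(C)CC(NC(=S)NCc2ccccc2)c2cc(Br)ccc2O1`), a thiourea analogue, which in this assay gives 54000 nM. Compound 3 (`CC1(C)CC(NC(=O)Nc2ccccc2Cl)c2cc(Cl)ccc2O1`) arises from compound 1 by the change (2-chlorophenyl in place of isopropyl on an amide-type nitrogen). For the measured compounds named here, with no measured step to lean on, the expected step from compound 1 to compound 3 of an at least 2.5-fold lower number from compound 1 to compound 3 (0.39 log units; beyond the scatter) is modest, toward stronger inhibition. Compound 3 is therefore estimated at 40000 nM, between 10000 nM and 100000 nM.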

Compound 3, half-maximal inhibitory concentration: 20000 nM
Estimate against measurement, compound 3: 2.0-fold (0.30 log units) above, and the stated range covers the measured number.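

In this assay, putting 2-chlorophenyl in place of isopropyl on the amide-type nitrogen gives an at least 5.0-fold lower number from compound 1 to compound 3 (0.69 log units; beyond the scatter), so the group at this position does affect inhibition. Compound 1 gives a limit rather than a number, so this step sets only a minimum size: the limit of > 100000 nM in this assay, at which 1 of the 3 values shown sits.

Whether the aromatic ring or its chlorine accounts for the change stays open, since a plain phenyl, a longer chain or a carboxylic acid on this nitrogen is not among the compounds shown. For the compounds shown here, compound 2 differs from the others in more than one place, so no step to it can be read.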